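Series notes: difluorophenyl for methoxyphenyl on the shared core

A few compounds are considered here, and "the series" means these few. Any claim that something is new, unique, unknown or untested is made for them only; others in the source may bear on it.

Compound 1 `COc1ccccc1-c1csc(N/N=C/c2cc(OC)c(OC)c(Br)c2Br)n1` is measured in a functional assay on Caco-2 cells (Homo sapiens) for inhibition, read by MTT assay, with a stated time of 48 h (a lower number here means a stronger inhibitor, a higher number a weaker inhibitor), only as a limit. In this assay compound 1 gives > 100000 nM, a limit of the assay and not a number. Compound 2 `COc1ccccc1-c1csc(N/N=C/c2cc(Br)c(OC)c(OC)c2)n1` is likewise measured only as a limit. In this assay compound 2 gives > 100000 nM, again a limit. Within the data shown here, the one measured step, a step that the two limits leave unreadable from compound 1 to compound 2, therefore cannot be read for size or direction. Both values sit at the same boundary, as the limit of > 100000 nM in this assay, at which 2 of the 2 values shown sit, records, so nothing in the measured pair tells how far either compound lies beyond it.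

Compound 3 `COc1cc(/C=N/Nc2nc(-c3ccc(F)c(F)c3)cs2)c(Br)c(Br)c1OC` differs from compound 1 by 3,4-difluorophenyl in place of 2-methoxyphenyl on an aromatic carbon. Among the measured compounds shown here, no measured step bears on this change. With both known values at the limit, compound 3 is estimated to sit near that limit as well, at 100000 nM, within 20000 nM to 300000 nM. The step this estimate implies is a number no higher from compound 1 to compound 3 (the limit leaves the size open), expected to be none beyond the scatter.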

Compound 3, half-maximal inhibitory concentration: 22800 nM
Compound 3: middle estimate off by 4.4-fold (0.64 log units), on the high side, within the range that was stated.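

Putting 3,4-difluorophenyl in place of 2-methoxyphenyl, on the aromatic carbon next to the ring nitrogen, gives an at least 4.3-fold lower number from compound 1 to compound 3 (0.64 log units; beyond the scatter) in this assay. This position is therefore the first place in the series where a single change is seen to yield a readable number, with compound 3 at 22800 nM. The true size of the step stays unknown because compound 1 sits at a limit, not at a number: the limit of > 100000 nM in this assay, at which 2 of the 3 values shown sit.

The compounds shown do not separate the entry of the two fluorines from the departure of the methoxy group, and a plain phenyl or a 4-chlorophenyl at this position would bear on that. As far as these compounds go, whether the second bromo counts once 3,4-difluorophenyl is in place also stays open, since the step between the two bromo patterns cannot be read at the limit.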